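Fluoro for methyl on the ester aryl ring

The source may hold more compounds than are shown below. What is called first, only, known or untested is meant among the compounds shown, and "the series" means these compounds.

Compound 1 `Cc1ccc(C(=O)OC2CCN(C)CC2)cc1` is the starting point of this comparison. In a functional assay on the whole organism with Mus musculus as the target (a higher number here means a more potent compound, by a factor of ten per unit of this negative logarithm, a lower number a less potent compound), compound 1 gives 1.17, the lowest of the three numbers in hand. Compound 3 `Cc1ccc(C(=O)OC2CCN(C)CC2)cc1F` gives 1.32 and compound 2 `CN1CCC(OC(=O)c2cccc(C#N)c2)CC1` gives 1.39; both differences from compound 1 lie within the scatter, so the three measured compounds cannot be ordered. Within the data shown here, the only single-point step measured is a number 0.15 log units higher from compound 1 to compound 3 (within the scatter).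

Compound 4 `CN1CCC(OC(=O)c2ccc(F)cc2)CC1` is not yet measured. It differs from compound 1 as follows: fluoro in place of methyl on an aromatic carbon. Among the measured compounds shown here, no measured pair swaps fluoro for methyl, so the step from compound 1 to compound 3, which swaps fluoro for hydrogen on a different aromatic carbon and stays within the scatter, is the closest guide, and compound 2 shows that another substituent change on this ring also stays within the scatter. The expected step in this assay from compound 1 to compound 4 is therefore small, a number 0.08 log units higher from compound 1 to compound 4 (within the scatter), with no direction that would stand beyond the scatter. Compound 4 is expected to give about 1.25, within a range from 0.85 to 1.65.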

Compound 4, logarithm of the reciprocal of the active concentration, log(1/C): 1.38
Beside the measured number, compound 4's estimate is 0.13 log units below it, within the range that was stated.
By their numbers in this assay, from the lowest: compounds 1, 3, 4 and 2 (each within the scatter of the next).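

In this assay, among these compounds, the first measured exchange of fluoro for methyl on an aromatic carbon, para to a large group, gives a number 0.21 log units higher from compound 1 to compound 4 (within the scatter). The methyl at this position can therefore give way to fluoro, with one heavy atom leaving and one entering, without a step that stands beyond the scatter, and the same holds for the addition of fluoro in a number 0.15 log units higher from compound 1 to compound 3 (within the scatter), so neither change on this ring separates itself from compound 1. The numbers show the size of this step only, and nothing measured alongside them bears on why it has this size.

The compounds shown leave open whether any other group at this place, such as an amine, a carboxylic acid or a longer alkyl chain, would give a step beyond the scatter in this assay. They also leave open how compound 1 and compound 4 stand against the shared core with plain hydrogen at this place, a comparison that would give the methyl and the fluoro a common reference.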